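Moving a Hydroxyl Group on a Shared Core

This account rests on a few compounds, and the source may have more. Where it says the series, first, only, none or still open, it means among the compounds named here.

Compound 1 `Oc1cccc(-c2cc(-c3ccccn3)cc(-c3cccc(O)c3)n2)c1` was tested in an assay on isolated protein for inhibition of DNA topoisomerase 1 (Homo sapiens), with a stated time of 30 min, tested at 100 uM (a higher number here means a stronger effect of the compound at the concentration tested, a lower number a weaker effect), where compound 1 gives 8.3%. Compound 2 `Oc1ccc(-c2cc(-c3ccccn3)cc(-c3cccc(O)c3)n2)cc1` carries 4-hydroxyphenyl in place of 3-hydroxyphenyl on an aromatic carbon, and in this assay compound 2 gives 2.4%, which made a number 5.9 percentage points lower from compound 1 to compound 2 (within the scatter). Compound 3 `Oc1cccc(-c2cc(-c3cccnc3)cc(-c3cccc(O)c3)n2)c1` differs from compound 1 by pyridin-3-yl in place of pyridin-2-yl on an aromatic carbon; in this assay compound 3 gives 2.1%, a step of a number 6.2 percentage points lower from compound 1 to compound 3 (within the scatter). Compound 4 `Oc1ccc(-c2cc(-c3cccnc3)cc(-c3cccc(O)c3)n2)cc1` is not yet measured; it differs from compound 3 by 4-hydroxyphenyl in place of 3-hydroxyphenyl on an aromatic carbon. This is the same kind of change as from compound 1 to compound 2, though here the place is meta to a pyridin-3-yl group rather than a pyridin-2-yl group. The earlier step of that kind was a number 5.9 percentage points lower from compound 1 to compound 2 (within the scatter). Because compound 3 already gives 2.1%, the step expected here is a number 1.1 percentage points lower from compound 3 to compound 4 (within the scatter), with little room downward. Compound 4 is estimated at 1%, expected between -5% and 8%.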

Compound 4, a percentage reported as inhibition, at one concentration (the size of the read-out at that concentration, not a potency): 5.9%
Estimate against measurement, compound 4: 4.9 percentage points below; the measured number falls inside the stated range.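

In this assay, putting 4-hydroxyphenyl in place of 3-hydroxyphenyl on the core of compound 3 gives a number 3.8 percentage points higher from compound 3 to compound 4 (within the scatter) and can be set beside the same change on the core of compound 1: the same change on two cores in this assay, a number 5.9 percentage points lower (within the scatter) from compound 1 to compound 2 and a number 3.8 percentage points higher (within the scatter) from compound 3 to compound 4, 9.7 percentage points apart, within the scatter of two such steps. Putting pyridin-3-yl in place of pyridin-2-yl on the core of compound 2 gives a number 3.5 percentage points higher from compound 2 to compound 4 (within the scatter) and can be compared in the same way: the same change on two cores in this assay, a number 6.2 percentage points lower (within the scatter) from compound 1 to compound 3 and a number 3.5 percentage points higher (within the scatter) from compound 2 to compound 4, 9.7 percentage points apart, within the scatter of two such steps. Neither change is shown to behave differently from one core to the other, but with every step inside the scatter, this does not show that either change has a real effect or carries over with a set size.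

The compounds shown leave open whether another group in place of the hydroxyl, such as an amine or a carboxylic acid, would move the read-out beyond the scatter.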